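Methyl placement on the aryl group: compound 3 to compound 4

The compounds below may be only part of what the source reports. "The series", "measured", "known", "first", "only" and "open" are said of these compounds alone.

Measured in a functional assay on KB cells (Homo sapiens) for antiproliferative activity, read by sulforhodamine B assay, with a stated time of 3 days; a higher number here means that more compound is needed for the effect, a lower number that less compound is needed:
- compound 1 `CCC1=C(O)c2c(oc(-c3ccc(C(C)C)cc3)cc2=O)C(CC)(CC)C1=O`: 8.13 uM
- compound 2 `CCC1=C(O)c2c(oc(-c3ccc(Br)cc3)cc2=O)C(CC)(CC)C1=O`: > 48.1 uM (a limit of the assay, not a number)
- compound 3 `CCC1=C(O)c2c(oc(-c3ccc(OC)cc3C)cc2=O)C(CC)(CC)C1=O`: 20.9 uM

In this assay, compound 3 has the higher of the two actual numbers, at 20.9 uM. The other actual number belongs to compound 1, and compound 2 stands only at a limit.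

Compound 4 `CCC1=C(O)c2c(oc(-c3ccc(OC)c(C)c3)cc2=O)C(CC)(CC)C1=O` carries 4-methoxy-3-methylphenyl in place of 4-methoxy-2-methylphenyl on an aromatic carbon.

Among the measured compounds shown here, no measured step makes this exact change. For the measured compounds named here, the only step between two actual numbers is a 2.6-fold higher number from compound 1 to compound 3 (0.41 log units; beyond the scatter), and it exchanges substituents on the aryl group, which this change does not do. The two steps involving compound 2 rest on its limit: an at least 5.9-fold higher number from compound 1 to compound 2 (0.77 log units; beyond the scatter) and an at least 2.3-fold lower number from compound 2 to compound 3 (0.36 log units; beyond the scatter). These steps show that this assay responds to changes in the aryl group, but none isolates the position of the methyl.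

A smaller step than a 2.6-fold higher number from compound 1 to compound 3 (0.41 log units; beyond the scatter) is therefore expected, most likely within the scatter and with no firm direction. The expected change is a 1.2-fold lower number from compound 3 to compound 4 (0.06 log units; within the scatter). For compound 4 the estimated value is 18 uM, with an expected range of 7 uM to 45 uM.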

Compound 4, concentration for half-maximal effect: 28.5 uM
Beside the measured number, compound 4's estimate is 1.6-fold (0.20 log units) below it, within the range that was stated.
By their numbers in this assay, from the lowest: compound 1; then compounds 3 and 4 (each within the scatter of the next). At a limit, above all of these: compound 2.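

In this assay, among the compounds shown here, moving the methyl from 4-methoxy-2-methylphenyl to 4-methoxy-3-methylphenyl gives a 1.4-fold higher number from compound 3 to compound 4 (0.13 log units; within the scatter), the first step that isolates methyl placement, and this placement does not separate the two compounds. The gap to the 4-isopropylphenyl group persists with the methyl in its new place, at a 3.5-fold higher number from compound 1 to compound 4 (0.54 log units; beyond the scatter), so that gap does not depend on which of these two methyl placements is present. Compound 2 stands at a limit of the assay and not at a number, so an at least 1.6-fold lower number from compound 2 to compound 4 (0.22 log units; that floor lies within the scatter) gives only a floor and does not place the 4-bromophenyl group relative to 4-methoxy-3-methylphenyl: the limit of > 48.1 uM in this assay, at which 1 of the 4 values shown sits.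

The compounds shown leave open whether any other group at the methyl's place, such as an ethyl, a hydroxyl or an amine, would move the number beyond the scatter. They also leave open what the methyl contributes at all, since no aryl group here carries the 4-methoxy group alone, and whether a carboxylic acid in place of the methoxy would hold the number near those of compound 3 and compound 4.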